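Inverting Two Centres: From Compound 3 to Compound 4

This account rests on a few compounds, and the source may have more. Where it says the series, first, only, none or still open, it means among the compounds named here.

In a functional assay on A2780 ADR cells (Homo sapiens) for cytotoxicity, read by MTT assay, with a stated time of 24 h (on this read-out lower numbers stand for stronger inhibition and higher numbers for weaker inhibition), compound 3 `CCCCC[C@H](C[C@@H](O)C[C@H]1CC=CC(=O)O1)OC` gives 18100 nM, the lowest of the three numbers shown, with compound 1 `CCCCC[C@@H](C[C@H](O)C[C@@H]1CC=CC(=O)O1)OC` at 26300 nM and compound 2 `CCCCC[C@H](C[C@@H](O)C[C@@H]1CC=CC(=O)O1)OC` at 91500 nM. Compound 4 `CCCCC[C@H](C[C@H](O)C[C@@H]1CC=CC(=O)O1)OC` is a further stereoisomer: the two compounds have the same atoms and bonds and differ only in configuration as drawn: 2 of 3 stereo elements differ; a stereocentre at a saturated chain carbon is drawn R in compound 3 and S in compound 4; a stereocentre at a saturated ring carbon is drawn R in compound 3 and S in compound 4. Among the compounds with values here, three measured steps bear on this change. Inverting two chain centres gave a 3.5-fold higher number from compound 1 to compound 2 (0.54 log units; beyond the scatter), inverting the ring centre alone gave a 5.1-fold lower number from compound 2 to compound 3 (0.70 log units; beyond the scatter), whereas complete mirror inversion gave a 1.5-fold lower number from compound 1 to compound 3 (0.16 log units; within the scatter). Compound 4 stands close in configuration to both compound 1 and compound 2, whose values bracket the likely outcome, so a modest rise in the number from compound 3 is expected, a 2.1-fold higher number from compound 3 to compound 4 (0.32 log units; beyond the scatter). Compound 4 is therefore estimated at 38000 nM, within a range of 13000 nM to 110000 nM.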

Compound 4, half-maximal inhibitory concentration: 30000 nM
Estimate against measurement, compound 4: 1.3-fold (0.10 log units) above; measured number inside the range.
By their numbers in this assay, from the lowest: compounds 3, 1 and 4 (each within the scatter of the next); then compound 2.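

In this assay, a single chain centre now carries a step of its own beyond the scatter: a 3.1-fold lower number from compound 2 to compound 4 (0.48 log units; beyond the scatter). Inverting a different chain centre alone gives a 1.1-fold higher number from compound 1 to compound 4 (0.06 log units; within the scatter), so the two chain centres do not count alike here. Inverting a chain centre and the ring centre together gives a 1.7-fold higher number from compound 3 to compound 4 (0.22 log units; within the scatter), and compound 2 alone stands apart from the other three.

All four compounds carry the same groups on the shared core, so the effect of configuration is known for this set alone. On these data alone, whether these differences would persist with an amine in place of the hydroxyl, or with a longer chain, remains open.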